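Bromo for methoxy on the aryl group of compound 2

This account rests on a few compounds, and the source may have more. Where it says the series, first, only, none or still open, it means among the compounds named here.

Compound 2 `CCCCN(CC)c1cc(C)nc2c1NC(=O)CN2c1ccc(OC)cc1C` and compound 1 `CCCCN(CC)c1cc(C)nc2c1NC(=O)CN2c1ccc(C)cc1Cl` share one core and differ only in the aryl group on the ring nitrogen. In an assay on HEK-293T cells for displacement of a labelled ligand from corticotropin-releasing factor receptor 1 (Homo sapiens), read by scintillation counting, with a stated time of 2 h (on this read-out lower numbers stand for stronger inhibition and higher numbers for weaker inhibition), compound 1 gives 4.4 nM, and compound 2 gives 4 nM; the step of a 1.1-fold lower number from compound 1 to compound 2 (0.04 log units; within the scatter) places the two within the scatter of each other, so compound 2 stands level with compound 1 on the numbers shown, not apart from it.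

Compound 3 `CCCCN(CC)c1cc(C)nc2c1NC(=O)CN2c1ccc(Br)cc1C` has not yet been measured. It differs from compound 2 by bromo in place of methoxy on an aromatic carbon. Among the measured compounds shown here, the only measured step bears on it indirectly: a 1.1-fold lower number from compound 1 to compound 2 (0.04 log units; within the scatter) swapped both substituents of the aryl group at once without moving the number beyond the scatter, which suggests that this aryl group tolerates changes of the kind now made. For the measured compounds named here, no measured pair isolates bromo against methoxy, so the expectation rests on that single step alone. Compound 3 is therefore expected to give 4.5 nM, within a range of 1.5 nM to 13 nM, and the step of a 1.1-fold higher number from compound 2 to compound 3 (0.05 log units; within the scatter) is estimated to stay within the scatter.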

Compound 3, inhibition constant: 4.4 nM
Compound 3: middle estimate off by 1.0-fold (0.01 log units), on the high side; low and high end bracket the measured number.
By their numbers in this assay, from the lowest: compounds 2, 1 and 3 (each within the scatter of the next).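

Bromo in place of methoxy, on the aromatic carbon para to a large group and with the methyl group left in place, gives a 1.1-fold higher number from compound 2 to compound 3 (0.04 log units; within the scatter) in this assay. This pair isolates a single substituent on the aryl group, which the earlier step could not do, and it shows that a group counted with 1 hydrogen-bond acceptor can give way to one counted with none while the two compounds stay level. The exchange of 2-chloro-4-methylphenyl for 4-bromo-2-methylphenyl gives no change at the digits printed from compound 1 to compound 3 (within the scatter), so all three aryl groups shown stand level on this read-out. Nothing measured here accounts for this result.

Whether this aromatic carbon would also stay level with an amine, a carboxylic acid or a longer chain such as butoxy remains open, since the only groups shown there are methoxy, bromo and, in the differently substituted aryl group of compound 1, methyl. The shared core is the same in all three compounds, so these numbers also say nothing about how a change to its amide hydrogen or to its other substituents would read.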